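The source may report more compounds than this note shows. Statements on the series, on what has been measured and on what is new or still open speak of the compounds shown alone.

Measured so far:
compound 1, `Nc1scc(CN2CCN(C3CCCCCC3)CC2)c1C(=O)c1ccc(Cl)cc1`: 0%
compound 2, `Nc1scc(CN2CCN(c3cc(F)cc(F)c3)CC2)c1C(=O)c1ccc(Cl)cc1`: 2%

In an assay on CHO cells for displacement of a labelled ligand from adenosine receptor A3 (Homo sapiens), read by scintillation counting, with a stated time of 120 min, tested at 10 uM (on this read-out lower numbers stand for less inhibition and higher numbers for more inhibition at the one concentration tested (going by the name of the read-out)), compound 1 gives 0% and compound 2 gives 2%. Compound 2 stands at the higher of the two numbers, but the step of a number 2 percentage points higher from compound 1 to compound 2 (within the scatter) is within the scatter, so the two cannot be set in order. For the measured compounds named here, the one measured step thus shows that exchanging cycloheptyl for 3,5-difluorophenyl on the ring nitrogen leaves the read-out flat near zero.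

Compound 3, `Nc1scc(CN2CCN(c3c(F)cccc3F)CC2)c1C(=O)c1ccc(Cl)cc1`, is not yet measured. It differs from compound 2 by 2,6-difluorophenyl in place of 3,5-difluorophenyl on an amine nitrogen in a ring, a rearrangement of the same atoms on the same ring nitrogen. Going by the values given here, no measured step addresses this particular change; the only step that bears on the same position, a number 2 percentage points higher from compound 1 to compound 2 (within the scatter), was within the scatter. With both measured compounds near zero and no step beyond the scatter, the expected change from compound 2 to compound 3 is a number 1 percentage points higher from compound 2 to compound 3 (within the scatter), that is, no step beyond the scatter. Compound 3 is therefore estimated at 3%, with a range from -5% to 15%.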

Compound 3, a percentage reported as inhibition, at one concentration (the size of the read-out at that concentration, not a potency): 4%
Compound 3: middle estimate off by 1 percentage points, on the low side, within the range that was stated.
By their numbers in this assay, from the lowest: compounds 1, 2 and 3 (each within the scatter of the next).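

In this assay, rearranging the two fluorines on the phenyl group, with the same atoms on the same ring nitrogen, gives a number 2 percentage points higher from compound 2 to compound 3 (within the scatter), so the 2,6-difluorophenyl and 3,5-difluorophenyl patterns cannot be told apart on this read-out. The second aryl-for-cycloheptyl exchange at this position gives a number 4 percentage points higher from compound 1 to compound 3 (within the scatter), so neither fluorine pattern separates from the cycloheptyl compound, and the position now stays flat across three groups rather than two. Nothing further is available to indicate what lies behind this flat read-out.

Still open, going by these compounds, is whether a group of another kind on this ring nitrogen, such as a benzyl, a pyridyl or a short chain ending in a carboxylic acid, would give a step beyond the scatter in this assay. On these data alone, the shared core is also constant across compounds 1, 2 and 3, so the effect of a change there, such as a methoxy group in place of the chlorine or an acetyl group on the free amine, remains unknown.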